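From compound 3 to compound 4: a single aryl swap

The source may report more compounds than this note shows. Statements on the series, on what has been measured and on what is new or still open speak of the compounds shown alone.

Going by the values given here, compound 3 `N#CC1=C(N)Oc2c(N)cc3nc4ccccc4nc3c2C12C(=O)N(Cc1cnnn1-c1cccc(C(F)(F)F)c1)c1ccccc12` is one of three compounds measured in an ADME assay on L02 cells (Homo sapiens) for antiproliferative activity, read by MTT assay, with a stated time of 48 h; a higher number here means a weaker inhibitor, a lower number a stronger inhibitor. In this assay, among the compounds with values here, compound 3 gives 38100 nM, the only actual number among the three. Compound 1 `N#CC1=C(N)Oc2c(c3nc4ccccc4nc3c3ccccc23)C12C(=O)N(Cc1cnnn1-c1ccc(F)cc1)c1ccccc12` gives a limit of the assay rather than a number, > 50000 nM. Compound 2 `COc1ccc(-n2nncc2CN2C(=O)C3(C(C#N)=C(N)Oc4c3c3nc5ccccc5nc3c3ccccc43)c3ccccc32)cc1` likewise gives a limit, > 50000 nM. The size of the step that the two limits leave unreadable from compound 1 to compound 2 cannot be read, because both of its ends sit at the limit of > 50000 nM in this assay, at which 2 of the 3 values shown sit. Compound 3 therefore stands alone as the compound with a readable value, while the other two stand at the limit.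

Compound 4 `COc1ccc(OC)c(-n2nncc2CN2C(=O)C3(C(C#N)=C(N)Oc4c(N)cc5nc6ccccc6nc5c43)c3ccccc32)c1` differs from compound 3 in one place: 2,5-dimethoxyphenyl in place of 3-(trifluoromethyl)phenyl on an aromatic nitrogen. Among the measured steps only a step that the two limits leave unreadable from compound 1 to compound 2 alters the group on the aromatic nitrogen, and its size is unreadable; no measured step shows how this kind of change moves the read-out. With nothing pointing either way, compound 4 is expected to sit close to compound 3 in this assay, with a step of a 1.0-fold higher number from compound 3 to compound 4 (0.02 log units; within the scatter) that is not expected to exceed the scatter. Compound 4 is accordingly estimated at 40000 nM, with a range from 20000 nM to 80000 nM, the upper end of which passes the assay limit.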

Compound 4, half-maximal inhibitory concentration: > 50000 nM
Compound 4 was reported as a limit; the forecaster's own chance of this, stated with the estimate: 40%; at least 1.2-fold (0.09 log units) between middle value and limit.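

Placing 2,5-dimethoxyphenyl where 3-(trifluoromethyl)phenyl stood on the aromatic nitrogen gives, in this assay, an at least 1.3-fold higher number from compound 3 to compound 4 (0.11 log units; that floor lies within the scatter). Going by these compounds alone, the earlier change on this nitrogen cannot be read, as both its ends are limits, whereas this step starts from a real number and so gives the first floor for a change at this position. As far as these compounds go, that floor lies within the scatter and no upper end can be read, so the swap shows no gain in strength, while its true size stays unknown. The result for compound 4 is a limit and not a number, and it adds to the values gathered at that same limit: the limit of > 50000 nM in this assay, at which 3 of the 4 values shown sit.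

From the compounds shown here alone, it remains open whether an aryl ring carrying an amine or a carboxylic acid, or a plain methyl on this nitrogen, would give a value that can be read in this assay. The compounds shown also include no pair that changes the shared core while keeping the aryl group the same, so the separate part played by the core cannot be told.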